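The compounds below may be only part of what the source reports. "The series", "measured", "known", "first", "only" and "open" are said of these compounds alone.

Working notes on the series. Compound 1 `Nc1cc(N)c2nc(-c3ccccc3)c(Sc3ccc(F)cc3)nc2c1` is the reference point. In a functional assay on A549 cells (Homo sapiens) for inhibition, read by sulforhodamine B assay, with a stated time of 48 h (on this read-out lower numbers stand for stronger inhibition of growth and higher numbers for weaker inhibition of growth), compound 1 gives 30900 nM. Compound 2 `COc1cc(CNc2nc3cc(N)cc(N)c3nc2-c2ccccc2)cc(OC)c1OC` gives 33100 nM in this assay, and these two numbers sit within the usual scatter of each other, so compound 1 holds one of two numbers that cannot be told apart. Compound 3 `CCOC(=O)[C@H](CCC(=O)O)NC(=O)c1ccc(CNc2nc3cc(N)cc(N)c3nc2-c2ccccc2)cc1` returns only a limit in this assay, < 100000 nM, and no number.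

Within the data shown here, no pair of measured compounds differs in a single place, so there is no measured step to guide the change considered here. Compound 4 `COc1ccc(Sc2nc3cc(N)cc(N)c3nc2-c2ccccc2)cc1` differs from compound 1 as follows: methoxy in place of fluoro on an aromatic carbon. Among the measured compounds shown here, the change is small and sits on a peripheral aromatic carbon, para to a large group, and nothing among the measured compounds speaks for a move beyond the scatter in this assay in either direction.

Compound 4 is therefore expected to land close to compound 1, with the step of a 1.0-fold lower number from compound 1 to compound 4 (0.01 log units; within the scatter) estimated as within the scatter. For compound 4 the expected value in this assay is 30000 nM, with a range from 10000 nM to 90000 nM.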

Compound 4, concentration for total growth inhibition: < 100000 nM
Compound 4: only a limit was reported (the forecaster's own chance of this, stated with the estimate: 15%); the middle value does not contradict the limit.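

Compound 4 returns only a limit in this assay, < 100000 nM, so no step from compound 1 to compound 4 can be read: the limit of < 100000 nM in this assay, at which 2 of the 4 values shown sit.

The compounds shown leave open whether methoxy in place of fluoro on an aromatic carbon shifts growth inhibition at all, and in which direction.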